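The compounds below may be only part of what the source reports. "The series", "measured", "known", "first", "only" and "open" are said of these compounds alone.

The measured compounds:
compound 1, `CN(C)c1cc2[nH]c(C3CCCCC3)nc2cc1NC(=O)c1cccs1`: > 100 ug/mL
compound 2, `CCCC(C)OC(=O)Nc1cc2nc(C3CCCCC3)[nH]c2cc1N(CC)CC`: > 100 ug/mL
compound 3, `CCN(CC)c1cc2[nH]c(C3CCCCC3)nc2cc1NC(=O)c1ccc(N(C)C)cc1`: "not determined" (no result reported)

In an ADME assay on Vero cells (Chlorocebus sabaeus) for cytotoxicity, read by resazurin assay, with a stated time of 3 days (on this read-out higher numbers stand for weaker inhibition and lower numbers for stronger inhibition), compound 1 gives > 100 ug/mL, which is a limit of the assay and not a number. Compound 2 likewise gives > 100 ug/mL in this assay, again a limit rather than a number. For compound 3 the entry in this assay reads "not determined" (no result reported), so no value is available for it. Within the data shown here, compound 1 thus stands at the limit of > 100 ug/mL in this assay, at which 2 of the 3 values shown sit, and no step between measured compounds can be drawn from these entries; of compound 1 and compound 2 it can only be said that both sit at the limit.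

Compound 4, `CN(C)c1cc2[nH]c(C3CCCCC3)nc2cc1NC(=O)OCC(F)(F)F`, has not been measured in this assay. It differs from compound 1 in one place: 2,2,2-trifluoroethoxy in place of thiophen-2-yl on a carbonyl carbon. The thiophen-2-yl group on the carbonyl carbon, whose other neighbour is an amide-type nitrogen, gives way to 2,2,2-trifluoroethoxy, so that ((thiophen-2-yl)carbonyl)amino becomes ((2,2,2-trifluoroethoxy)carbonyl)amino.

With the two shown values sitting at the limit, the step of a number no higher from compound 1 to compound 4 (the limit leaves the size open) is expected to be none beyond the scatter. Compound 4 is therefore expected to give about 100 ug/mL in this assay, with a range from 50 ug/mL to 200 ug/mL, most probably reported again only as a limit.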

Compound 4, half-maximal inhibitory concentration: > 100 ug/mL
Compound 4 ended at the assay's limit (the forecaster's own chance of this, stated with the estimate: 80%); the middle value sits exactly at the limit.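

In this assay compound 4 gives > 100 ug/mL, which is a limit of the assay and not a number. Compound 1 also stands at a limit, so no step between compound 1 and compound 4 can be read: the limit of > 100 ug/mL in this assay, at which 3 of the 4 values shown sit.

The compounds shown leave open what actual number any of them would give in this assay, and whether 2,2,2-trifluoroethoxy in place of thiophen-2-yl changes it.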